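This account rests on a few compounds, and the source may have more. Where it says the series, first, only, none or still open, it means among the compounds named here.

Measured compounds:
compound 1 `CCOC(=O)c1ccc(NC(=O)NCc2c[nH]nn2)cc1`, 7750 nM
compound 2 `O=C(NCc1ccncc1)Nc1ccc(S(=O)(=O)N2CC3CCC(C2)O3)cc1`, 279 nM
compound 3 `NS(=O)(=O)c1ccc(NC(=O)NCc2ccncc2)cc1`, 14300 nM

In an assay on isolated protein for activation of Nicotinamide phosphoribosyltransferase (Homo sapiens) (on this read-out lower numbers stand for an effect already at smaller amounts and higher numbers for an effect only at larger amounts of compound), compound 1 gives the second highest of the three numbers; compound 3 is nearest, within the scatter, while compound 2 lies far lower, beyond it.

The step from compound 1 to compound 4 `CCOC(=O)c1ccc(NC(=O)NCc2ccnnc2)cc1` is pyridazin-4-yl in place of 1H-1,2,3-triazol-4-yl on a saturated chain carbon bound to an amide-type nitrogen. For the measured compounds named here, no measured step touches this part of the molecule: the only quantified change, a 51-fold higher number from compound 2 to compound 3 (1.71 log units; beyond the scatter), is on a sulfonyl sulfur and gives no reading on the heteroaryl. Going by the values given here, compound 1 and compound 3 differ in two places at once, so their pair yields no isolated step; compound 1 gives 7750 nM and compound 3 gives 14300 nM, and these two values lie within the scatter of each other. On this basis no step beyond the scatter is expected from compound 1 to compound 4 in this assay, direction open.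

Compound 4 is therefore estimated at 7000 nM, between 2000 nM and 25000 nM, meaning an expected step of a 1.1-fold lower number from compound 1 to compound 4 (0.04 log units; within the scatter).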

Compound 4, half-maximal effective concentration: > 100000 nM
Compound 4: no number, only a limit (the forecaster's own chance of this, stated with the estimate: 15%); middle value at least 14-fold (1.15 log units) away from the limit.
By their numbers in this assay, from the lowest: compound 2; then compounds 1 and 3 (each within the scatter of the next). At a limit, above all of these: compound 4.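

In this assay, the group on the saturated chain carbon bound to an amide-type nitrogen now has a measured effect of its own: pyridazin-4-yl in place of 1H-1,2,3-triazol-4-yl gives an at least 12-fold higher number from compound 1 to compound 4 (1.11 log units; beyond the scatter). The value of compound 4 is a limit and not a number, so this step has no upper end: the limit of > 100000 nM in this assay, at which 1 of the 4 values shown sits. The change alters ring size and hydrogen-bond donor count together, and this single pair cannot separate the two.

Open, on these data alone, is whether the same exchange has a similar effect on the sulfonyl-bearing core of compound 2. Also open, as far as these compounds go, is how a phenyl or an imidazole ring would read on the same chain carbon, as either could help to separate ring size from the donor.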